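The compounds below may be only part of what the source reports. "The series", "measured", "known", "first", "only" and "open" are said of these compounds alone.

Measured so far:
Compound 1, `COc1ccccc1/C=c1/[nH]c(=O)/c(=C\c2ccccc2OC)[nH]c1=O` — in a functional assay on A549 cells (Homo sapiens) for cytotoxicity, read by CCK-8 assay, with a stated time of 72 h (on this read-out lower numbers stand for stronger inhibition and higher numbers for weaker inhibition), compound 1 gives "not active" (no number reported), with no number reported.
Compound 2, `C=CCn1c(=O)/c(=C\c2cc(F)ccc2C)[nH]c(=O)/c1=C\c1ccccc1OC` — in this assay compound 2 gives 4900 nM.

Compound 2 is the only compound with a single number in this assay; compound 1 carries only the qualitative entry given above, so no step between measured compounds can be drawn, and nothing is known of how a change of this kind shifts the read-out.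

Compound 3, `C=CCn1c(=O)/c(=C\c2cc(Br)ccc2F)[nH]c(=O)/c1=C\c1ccccc1OC`, has not been measured. It differs from compound 2 by 5-bromo-2-fluorophenyl in place of 5-fluoro-2-methylphenyl on a double-bonded chain carbon bound to an aromatic carbon. Among the measured compounds shown here, with no comparable step to lean on, the expected step of a 1.1-fold lower number from compound 2 to compound 3 (0.04 log units; within the scatter) is small, within the usual scatter, with no clear direction. Compound 3 is therefore estimated at 4500 nM in this assay, with a likely range from 1500 nM to 14000 nM.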

Compound 3, half-maximal inhibitory concentration: "not active" (no number reported)
Compound 3 has no reported number here; there is nothing to compare the estimate with.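

In this assay, among the compounds shown here, compound 3 gives "not active" (no number reported), and no step from compound 2 can be read from that entry. Nothing measured here bears on this result. The compounds shown leave open how far 5-bromo-2-fluorophenyl in place of 5-fluoro-2-methylphenyl shifts the read-out.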